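The source may report more compounds than this note shows. Statements on the series, on what has been measured and on what is new or still open speak of the compounds shown alone.

The series rests on a single vanilloid-type amide bearing a long chain linked through a chalcogen atom. Compound 1 `CCCCCCCCCCCCCCCC[Se]CCC(=O)NCc1ccc(O)c(OC)c1` carries a selenium atom and a fully saturated chain. Compound 2 `CCCCC/C=C\C/C=C\CCCCCCCC[Se]CCC(=O)NCc1ccc(O)c(OC)c1` keeps the selenium atom but ends the chain in a deca-1,4-dien-1-yl group. Compound 3 `CCCCC/C=C\C/C=C\CCCCCCCCSCCC(=O)NCc1ccc(O)c(OC)c1` is the sulfur counterpart of compound 2; the difference between the two cores is not broken down here. Compound 4 `CCCCCCCCCCCCCCCCSCCC(=O)NCc1ccc(O)c(OC)c1` pairs the sulfur atom with the saturated chain of compound 1.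

In an assay on HEK293 cells for antagonist activity at transient receptor potential cation channel subfamily V member 2 (Rattus norvegicus), read by fluorescence and calcium flux, with a stated time of 5 min (on this read-out higher numbers stand for weaker inhibition and lower numbers for stronger inhibition), compound 1 gives 4300 nM. In this assay compound 2 gives 1400 nM, and in this assay compound 3 gives 1400 nM, level with compound 2 at the digits reported and together the lowest two numbers of the three. Going by the values given here, the one change measured in both directions so far, (octyl in place of deca-1,4-dien-1-yl on a saturated chain carbon, eight bonds along the chain from a selenium atom), produced a 3.1-fold higher number from compound 2 to compound 1 (0.49 log units; beyond the scatter).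

The same kind of change is made from compound 3 to compound 4, (octyl in place of deca-1,4-dien-1-yl on a saturated chain carbon, eight bonds along the chain from a sulfur), but on a sulfur chain rather than a selenium one, so the surroundings of the place are not identical. Because compound 3 sits at 1400 nM and the corresponding step on the selenium series was a 3.1-fold higher number from compound 2 to compound 1 (0.49 log units; beyond the scatter), the step from compound 3 to compound 4 is expected to be about a 2.9-fold higher number from compound 3 to compound 4 (0.46 log units; beyond the scatter). Compound 4 is therefore estimated at 4000 nM, with a likely range from 1800 nM to 9000 nM.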

Compound 4, half-maximal inhibitory concentration: 3800 nM
For compound 4 the middle estimate is 1.1-fold (0.02 log units) above the measured one, within the range that was stated.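

In this assay, putting octyl in place of deca-1,4-dien-1-yl on the sulfur chain gives a 2.7-fold higher number from compound 3 to compound 4 (0.43 log units; beyond the scatter), so the saturated chain again gives the weaker inhibition, as it did on the selenium chain. Set side by side, the two steps do not differ by more than the usual variation of such measurements, and within this series the change carries from the selenium core to the sulfur core with its direction and its size intact: the same change on two cores in this assay, a 3.1-fold higher number (0.49 log units; beyond the scatter) from compound 2 to compound 1 and a 2.7-fold higher number (0.43 log units; beyond the scatter) from compound 3 to compound 4, 1.1-fold (0.05 log units) apart, within the scatter of two such steps. This agreement rests on just two cores that differ only in the selenium or sulfur atom, so it does not establish that the change would keep its size on any other core, and it gives no explanation of why the two chains differ.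

The compounds shown leave open how the same change would read with an oxygen atom or a methylene group in place of the selenium or sulfur atom, and whether a chain with a single double bond would sit with the saturated chain or with the deca-1,4-dien-1-yl chain. They also leave open what a longer chain, or a chain carrying an amine or a carboxylic acid, would do on either core.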